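Thiophene-bearing pyridines: antiproliferative read-out, one ring change

This account rests on a few compounds, and the source may have more. Where it says the series, first, only, none or still open, it means among the compounds named here.

Among the compounds with values here, compound 1 `C(=C/c1cccs1)\c1cc(-c2cccs2)cc(-c2cccs2)n1` and compound 2 `c1coc(-c2ccnc(-c3ccco3)c2)c1` are the two measured members. In a functional assay on A549 cells (Homo sapiens) for antiproliferative activity (on this read-out higher numbers stand for an effect only at larger amounts of compound and lower numbers for an effect already at smaller amounts), compound 1 gives 118000 nM; compound 2 gives 118000 nM in this assay, which is level with compound 1 at the digits recorded, within the scatter. Compound 3 `c1csc(-c2cc(-c3cccs3)nc(-c3cccs3)c2)c1` is not yet measured. It differs from compound 1 in one place: thiophen-2-yl in place of 2-(thiophen-2-yl)ethenyl on an aromatic carbon. Within the data shown here, no step between measured compounds exists here. The step from compound 1 to compound 3 is expected to be no change at the digits printed from compound 1 to compound 3 (within the scatter), none beyond the scatter. For compound 3 the estimate in this assay is 118000 nM, between 40000 nM and 350000 nM.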

Compound 3, half-maximal effective concentration: 118000 nM
For compound 3 middle estimate and measured number coincide at the digits printed; the range from low to high includes it.
By their numbers in this assay, from the lowest: compounds 1, 2 and 3 (each within the scatter of the next).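

In this assay, within the data shown here, the first step at this position reads no change at the digits printed from compound 1 to compound 3 (within the scatter) with thiophen-2-yl in place of 2-(thiophen-2-yl)ethenyl on the aromatic carbon next to the ring nitrogen. Among these compounds, compounds 1 and 2 are joined by no single step, so only this pair shows that removing the double bond outside aromatic rings, while a five-membered aromatic ring stays at this position, leaves the read-out level. Nothing available explains this result. Still open, as far as these compounds go, is whether an amine or a carboxylic acid at this position would give a different read-out.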